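Solubility notes: replacing the aryl amide with a basic ring

This account rests on a few compounds, and the source may have more. Where it says the series, first, only, none or still open, it means among the compounds named here.

Measured compounds in a physicochemical assay for solubility, at pH 7.4; on this read-out lower numbers stand for lower solubility and higher numbers for higher solubility:
Compound 1 `O=C(c1ccc(Cl)nc1)N1CCC(NS(=O)(=O)c2cc(S(=O)(=O)c3ccccc3)ccc2C(F)(F)F)CC1` gives 1700 nM.
Compound 2 `CN(C)c1ccc(C(=O)N2CCC(NS(=O)(=O)c3cc(S(=O)(=O)c4ccccc4)ccc3C(F)(F)F)CC2)cn1` gives 6700 nM.
Compound 3 `O=C(C1CCNCC1)N1CCC(NS(=O)(=O)c2cc(S(=O)(=O)c3ccccc3)ccc2C(F)(F)F)CC1` reports only a limit, > 100000 nM.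

Compound 2 stands highest of the two numbers shown; its nearest neighbour is compound 1, with a 3.9-fold higher number from compound 1 to compound 2 (0.60 log units; beyond the scatter). The third value is the limit of > 100000 nM in this assay, at which 1 of the 3 values shown sits.

Compound 4 `O=C([C@H]1CCNC1)N1CCC(NS(=O)(=O)c2cc(S(=O)(=O)c3ccccc3)ccc2C(F)(F)F)CC1` differs from compound 2 at the carbonyl carbon: pyrrolidin-3-yl in place of 6-(dimethylamino)pyridin-3-yl on a carbonyl carbon.

The measured steps that bear on this are an at least 14-fold higher number from compound 2 to compound 3 (1.17 log units; beyond the scatter) and an at least 58-fold higher number from compound 1 to compound 3 (1.76 log units; beyond the scatter), both large and both upward on moving to a saturated ring with a hydrogen-bond donor. A large upward step is therefore expected, a 15-fold higher number from compound 2 to compound 4 (1.17 log units; beyond the scatter), and the assay may again return only its limit. Compound 4 is estimated at 100000 nM, with a range of 30000 nM to 300000 nM.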

Compound 4, solubility: 77000 nM
Beside the measured number, compound 4's estimate is 1.3-fold (0.11 log units) above it; the measured number falls inside the stated range.
By their numbers in this assay, from the lowest: compound 1; then compound 2; then compound 4. At a limit, above all of these: compound 3.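

In this assay the high end at this carbonyl carbon does not rest on piperidin-4-yl alone: pyrrolidin-3-yl, a five-membered non-aromatic ring, gives an 11-fold higher number from compound 2 to compound 4 (1.06 log units; beyond the scatter) and a 45-fold higher number from compound 1 to compound 4 (1.66 log units; beyond the scatter) while returning a number rather than a limit. Compound 3 reports only a limit: the limit of > 100000 nM in this assay, at which 1 of the 4 values shown sits. Against that limit the step reads an at least 1.2-fold lower number from compound 3 to compound 4 (0.11 log units; that floor lies within the scatter), which leaves the order of these two open.

Open, from the compounds shown here alone, is whether the hydrogen on the ring nitrogen carries these steps, as an acetyl group on that nitrogen would test. Also open, going by these compounds, is whether the opposite stereocentre in pyrrolidin-3-yl reads the same.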